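The source may report more compounds than this note shows. Statements on the series, on what has been measured and on what is new or still open speak of the compounds shown alone.

Measured so far in an assay for inhibition of inositol hexakisphosphate kinase 2 (Homo sapiens), read by colorimetric assay, coupled enzyme assay and malachite green, with a stated time of 120 min, in the presence of a further agent that is not named here; a lower number here means a stronger inhibitor, a higher number a weaker inhibitor:
- compound 1 `O=C(O)/C=C/c1ccc2noc(-c3ccc(OC(F)(F)F)cc3)c2c1`: 320 nM
- compound 2 `Cc1cccc(-c2onc3ccc(/C=C/C(=O)O)cc23)c1`: 290 nM
- compound 3 `O=C(O)c1ccc2noc(-c3ccc(Oc4ccccn4)cc3)c2c1`: 1190 nM

Compound 3 gives the highest number of the three in this assay; compound 1 and compound 2 both sit lower, each beyond the scatter, so compound 3 is the weakest inhibitor of the set. Compound 4 `O=C(O)c1ccc2noc(-c3ccc(NC(=O)c4ccncn4)cc3)c2c1` differs from compound 3 by ((pyrimidin-4-yl)carbonyl)amino in place of (pyridin-2-yl)oxy on an aromatic carbon. Within the data shown here, no measured pair shows this kind of change, so its effect in this assay is open. The expected step from compound 3 to compound 4 is a 1.5-fold lower number from compound 3 to compound 4 (0.17 log units; within the scatter), a modest gain that may still fall within the scatter. Compound 4 is therefore estimated at 800 nM in this assay, with a range from 250 nM to 2600 nM.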

Compound 4, half-maximal inhibitory concentration: 720 nM
The estimate for compound 4 lay 1.1-fold (0.05 log units) above the measured number; the range from low to high includes it.
By their numbers in this assay, from the lowest: compounds 2 and 1 (each within the scatter of the next); then compounds 4 and 3 (each within the scatter of the next).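

In this assay, the aromatic carbon para to a large group takes ((pyrimidin-4-yl)carbonyl)amino in place of (pyridin-2-yl)oxy with a 1.7-fold lower number from compound 3 to compound 4 (0.22 log units; within the scatter), so this larger group, with its carbonyl and amide hydrogen, leaves the number within the scatter. The step replaces the linking atoms and the ring together, and their separate contributions cannot be read from it. No supporting measurement bears on this result.

From the compounds shown here alone, whether the pyrimidine ring or the amide linkage matters more remains open. Going by these compounds, how a sulfonamide or a simple amine would read in this place also remains open.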